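A few compounds are considered here, and "the series" means these few. Any claim that something is new, unique, unknown or untested is made for them only; others in the source may bear on it.

In a functional assay on SK-OV-3 cells (Homo sapiens) for inhibition, read by CCK-8 assay, with a stated time of 70 h (on this read-out lower numbers stand for stronger inhibition and higher numbers for weaker inhibition), compound 1 `COc1ccc(COc2ccc(OCCOCCNC3CCCC3)cc2)cc1` gives 15700 nM. Compound 3 `CC(C)(C)OC(=O)n1ccc(NCCOCCOc2ccc(OCc3ccccc3)cc2)c1` gives 13000 nM in this assay, and compound 2 `c1ccc2cc(OCCOCCNC3CCCC3)ccc2c1` gives 40600 nM. On these three numbers compound 1 stands second highest: its number and that of compound 3 lie within the scatter of each other, whereas the number of compound 2 is higher by a margin beyond the scatter. Among the compounds with values here, no pair among the measured compounds differs in only one place, so no single-change step in this assay is available for comparison.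

Compound 4 `O=[N+]([O-])c1ccccc1COc1ccc(OCCOCCNC2CCCC2)cc1` is not yet measured. Relative to compound 1 the change is 2-nitrophenyl in place of 4-methoxyphenyl on a saturated chain carbon bound to an oxygen on an aromatic ring. Within the data shown here, nothing measured so far shows how this assay responds to a change at that place, so no step beyond the scatter is expected. The step is estimated as a 1.1-fold lower number from compound 1 to compound 4 (0.05 log units; within the scatter), with a wide range around it. For compound 4 the expected value in this assay is 14000 nM, with the range 5000 nM to 40000 nM.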

Compound 4, half-maximal inhibitory concentration: 5370 nM
Beside the measured number, compound 4's estimate is 2.6-fold (0.42 log units) above it; low and high end bracket the measured number.
By their numbers in this assay, from the lowest: compound 4; then compounds 3 and 1 (each within the scatter of the next); then compound 2.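

In this assay, the place on a saturated chain carbon bound to an oxygen on an aromatic ring proves responsive: 2-nitrophenyl in place of 4-methoxyphenyl gives a 2.9-fold lower number from compound 1 to compound 4 (0.47 log units; beyond the scatter), the first single-change step available in the series. The aryl group at this place can therefore shift the read-out beyond the scatter, although the step is modest and a single pair establishes no trend. No available evidence accounts for the size or direction of this step.

The step removes 4-methoxyphenyl and introduces 2-nitrophenyl together, so the shown compounds cannot separate the contribution of leaving the first group from that of adding the second. Also open, from the compounds shown here alone, is whether a phenyl ring bearing an amine, a nitrile or a carboxylic acid at this place would match compound 4 or compound 1.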